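A few compounds are considered here, and "the series" means these few. Any claim that something is new, unique, unknown or untested is made for them only; others in the source may bear on it.

Measured so far in a toxicity assay on THP-1 cells (Homo sapiens) for inhibition; a higher number here means that more compound is tolerated, a lower number that less compound is tolerated
compound 1 `COc1ccc(-c2cnc(NC(=O)c3ccc(F)cc3)n2Cc2ccccc2)cc1` gives > 100000 nM (a limit)
compound 2 `O=C(Nc1ncc(-c2ccccc2)o1)c1ccc(Cl)cc1` gives 10000 nM (a number)

Compound 1 sits at > 100000 nM here, a limit of the assay and not a number. Compound 3 `CCn1c(-c2ccc(OC)cc2)cnc1NC(=O)c1ccc(F)cc1` differs from compound 1 only by benzyl to ethyl (methyl in place of phenyl on a saturated chain carbon bound to an aromatic nitrogen), that is, methyl in place of phenyl on a saturated chain carbon bound to an aromatic nitrogen. Among the measured compounds shown here, no measured pair shows this change, so no step beyond the scatter is expected in this assay, and the result may again be only a limit. The step expected is small (a number no higher from compound 1 to compound 3 (the limit leaves the size open)). For compound 3 the estimate is 100000 nM (expected range 40000 nM to 200000 nM).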

Compound 3, half-maximal cytotoxic concentration: > 100000 nM
Compound 3 was reported as a limit; the forecaster's own chance of this, stated with the estimate: 65%; the middle value lies on the limit itself.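

Among the compounds shown here, compound 1 and compound 3 both sit at a limit and not at a number, so no step between them can be read: the limit of > 100000 nM in this assay, at which 2 of the 3 values shown sit. The compounds shown leave open what the change from benzyl to ethyl does to tolerance.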